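A Methyl Added to the Benzamide of Compound 1

The source may report more compounds than this note shows. Statements on the series, on what has been measured and on what is new or still open speak of the compounds shown alone.

Compound 1 `CN(C)c1cc2[nH]c(C3CCCCC3)nc2cc1NC(=O)c1ccccc1` was assessed in an ADME assay on Vero cells (Chlorocebus sabaeus) for cytotoxicity, read by resazurin assay, with a stated time of 3 days; a lower number here means a stronger inhibitor, a higher number a weaker inhibitor. There compound 1 gave only a limit, > 100 ug/mL. Compound 2 `CCCCOC(=O)Nc1cc2nc(C3CCCCC3)[nH]c2cc1N(CC)CCN(C)C` likewise reached only a limit in this assay, namely > 100 ug/mL. Compound 3 `CCOCCOC(=O)Nc1cc2nc(C3CCCCC3)[nH]c2cc1N1CCCC1` also gave a limit in this assay, namely > 100 ug/mL. Going by the values given here, all three values sit at the limit of > 100 ug/mL in this assay, at which 3 of the 3 values shown sit, so compound 1 stands level with compounds 2 and 3, and no measured step between any two of them exists. Compound 4 `Cc1ccc(C(=O)Nc2cc3nc(C4CCCCC4)[nH]c3cc2N(C)C)cc1` differs from compound 1 by methyl in place of hydrogen on an aromatic carbon. Because all three measured values sit at the limit of > 100 ug/mL in this assay, at which 3 of the 3 values shown sit, the step that the limit leaves unreadable from compound 1 to compound 4 in this assay is expected to be none beyond the scatter. Compound 4 is therefore estimated at 150 ug/mL, with a range from 70 ug/mL to 400 ug/mL.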

Compound 4, half-maximal inhibitory concentration: > 100 ug/mL
Compound 4 ended at the assay's limit (the forecaster's own chance of this, stated with the estimate: 80%); the middle value is on the limit's open side.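

Compound 1 and compound 4 both end at a limit in this assay, so no step can be read between them. The compounds shown leave open how large any effect of the methyl on the benzamide is, as every value is a limit: the limit of > 100 ug/mL in this assay, at which 4 of the 4 values shown sit.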